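Dropping One Methoxy Group: Compound 2 to Compound 3

The source may hold more compounds than are shown below. What is called first, only, known or untested is meant among the compounds shown, and "the series" means these compounds.

Measured so far:
compound 1, `COc1ccc(-c2cc(/C=C/C(=O)c3ccc(N)cc3)[nH]n2)cc1`: 95%
compound 2, `COc1cc(-c2cc(/C=C/C(=O)c3ccc(N)cc3)[nH]n2)cc(OC)c1OC`: 94%

Both were tested in a functional assay on 786-0 cells (Homo sapiens) for cytotoxicity, read by sulforhodamine B assay, with a stated time of 48 h, tested at 0.1 uM; a lower number here means a stronger effect, a higher number a weaker effect of the compound at the concentration tested. Compound 1 gives 95% and compound 2 gives 94%. These numbers differ by less than the usual scatter, so the two compounds cannot be told apart, and both show only a weak effect at this concentration. Compound 3, `COc1ccc(-c2cc(/C=C/C(=O)c3ccc(N)cc3)[nH]n2)cc1OC`, is not yet measured. It differs from compound 2 by hydrogen in place of methoxy on an aromatic carbon. Since compound 1 and compound 2 sit so close, no step beyond the scatter is expected in this assay. Compound 3 is expected to give 94%, within 85% to 100%. The step this estimate implies, no change at the digits printed from compound 2 to compound 3 (within the scatter), is expected to stay within the scatter.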

Compound 3, a percentage reported as activity, at one concentration (the size of the read-out at that concentration, not a potency): 95%
Compound 3: the middle estimate sits 1 percentage points below what was measured; the measured number falls inside the stated range.
By their numbers in this assay, from the lowest: compounds 2, 1 and 3 (each within the scatter of the next).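

In this assay, hydrogen in place of methoxy gives a number 1 percentage points higher from compound 2 to compound 3 (within the scatter) and, on the same kind of aromatic carbon, methoxy in place of hydrogen gives no change at the digits printed from compound 1 to compound 3 (within the scatter) as the second single-place comparison. Neither swap separates its pair of compounds, so neither methoxy group shows a measurable role at the concentration tested. No available information explains this result. Still open, as far as these compounds go, is whether a hydroxyl, an amine or a carboxylic acid on this ring would give a step beyond the scatter.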